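A few compounds are considered here, and "the series" means these few. Any claim that something is new, unique, unknown or untested is made for them only; others in the source may bear on it.

Measured so far:
compound 1, `Cc1ccc(NC(=O)N[C@H](C)c2ccccc2)cc1`: 64%
compound 2, `C[C@@H](NC(=O)Nc1ccc(F)cc1F)c1ccccc1`: 93%

In an ADME assay on the whole organism with Oryza sativa as the target, tested at 10 uM (on this read-out lower numbers stand for a stronger effect and higher numbers for a weaker effect at the one concentration tested), compound 2 gives 93%, the higher of the two numbers and so the weaker effect; compound 1 lies beyond the scatter below it. Compound 3, `Cc1ccc(NC(=O)N[C@H](C)c2ccccc2)c(F)c1`, is not yet measured. It differs from compound 2 in one place: methyl in place of fluoro on an aromatic carbon. Compound 3 now carries the same methyl group as compound 1, which gives 64% in this assay. A downward step of moderate size, toward a stronger effect, is therefore expected: a number 17 percentage points lower from compound 2 to compound 3 (beyond the scatter). Compound 3 is estimated to give about 76%, with a range from 56% to 94%.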

Compound 3, a percentage reported as activity, at one concentration (the size of the read-out at that concentration, not a potency): 99%
The estimate for compound 3 lay 23 percentage points below the measured number, and the stated range ends below it.
By their numbers in this assay, from the lowest: compound 1; then compounds 2 and 3 (each within the scatter of the next).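

In this assay, methyl and fluoro cannot be told apart at this position, para to a large group: the swap gives a number 6 percentage points higher from compound 2 to compound 3 (within the scatter) and nothing more. The methyl group shared with compound 1 therefore does not carry that compound's stronger effect on its own, since fluoro in place of hydrogen on an aromatic carbon gives a number 35 percentage points higher from compound 1 to compound 3 (beyond the scatter) on the same core. No measurement at hand explains this. Still open, as far as these compounds go, is whether a chloro or methoxy group at this position would behave like methyl and fluoro. Also open, from the compounds shown here alone, is whether removing the fluoro from compound 2's other aromatic carbon would restore the stronger effect.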